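Ester-to-amide change on the oxazole of compound 1: cytotoxicity notes

The source may hold more compounds than are shown below. What is called first, only, known or untested is meant among the compounds shown, and "the series" means these compounds.

Measured so far:
- compound 1, `CCOC(=O)c1cc(CCCOc2c(C)cc(-c3noc(C(F)(F)F)n3)cc2C)on1`: 17200 nM
- compound 2, `CCOC(=O)c1cc(CCCOc2ccc(-c3noc(C(F)(F)F)n3)cc2F)on1`: 60200 nM

Among the compounds with values here, in an ADME assay on HeLa cells (Homo sapiens) for cytotoxicity, read by crystal violet staining, with a stated time of 72 h (a higher number here means that more compound is tolerated, a lower number that less compound is tolerated), compound 1 gives 17200 nM, the lower of the two numbers known, so less of it is tolerated than of compound 2, which gives 60200 nM; the two differ on a different ring and no single step links them.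

Compound 3, `Cc1cc(-c2noc(C(F)(F)F)n2)cc(C)c1OCCCc1cc(C(=O)N(C)C)no1`, is not yet measured. It differs from compound 1 in one place: dimethylamino in place of ethoxy on a carbonyl carbon. Nothing measured in this series shows what such an exchange does in this assay, so the step from compound 1 to compound 3 is expected to be small and in no settled direction, likely within the usual scatter; the estimated step is a 1.2-fold higher number from compound 1 to compound 3 (0.07 log units; within the scatter). For compound 3 the estimate is therefore 20000 nM, in the range 8000 nM to 50000 nM.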

Compound 3, half-maximal cytotoxic concentration: 13200 nM
The estimate for compound 3 lay 1.5-fold (0.18 log units) above the measured number; low and high end bracket the measured number.
By their numbers in this assay, from the lowest: compounds 3 and 1 (each within the scatter of the next); then compound 2.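

In this assay, within the data shown here, the exchange of ethoxy for dimethylamino on a carbonyl carbon, the first single-place change, gives a 1.3-fold lower number from compound 1 to compound 3 (0.11 log units; within the scatter) and so stays within the usual scatter. On the core of compound 1, the assay therefore does not tell the 3-(ethoxycarbonyl)-1,2-oxazol-5-yl group from the 3-(dimethylcarbamoyl)-1,2-oxazol-5-yl group, and the ester is not needed to hold the number where it stands. Nothing at hand bears on why the two groups read alike.

Still open, as far as these compounds go, is whether this holds for groups further from these two on the same carbonyl carbon, such as a carboxylic acid or an amide that keeps an amide hydrogen. Equally open, from the compounds shown here alone, is whether dimethylamino for ethoxy reads the same way on the core of compound 2.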